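The compounds below may be only part of what the source reports. "The series", "measured", "known", "first", "only" and "open" are said of these compounds alone.

Measured compounds:
compound 1, `CC(C)[C@H](NC(=O)COc1cccc2ccccc12)C(=O)N[C@@H](CC(=O)O)C(=O)COC(=O)c1c(Cl)cccc1Cl`: 10600 nM
compound 2, `CC(C)[C@H](NC(=O)COc1cccc2ccccc12)C(=O)N[C@@H](CC(=O)O)C(=O)COc1ccccc1`: 14000 nM

In a functional assay on Jurkat cells (Homo sapiens) (a lower number here means a stronger inhibitor, a higher number a weaker inhibitor), compound 2 gives 14000 nM. Going by the values given here, the only neighbouring step, a 1.3-fold higher number from compound 1 to compound 2 (0.12 log units; within the scatter), shows a change within the scatter, so compound 2 and compound 1 cannot be ranked against each other. Compound 3, `CC(C)[C@H](NC(=O)COc1cccc2ccccc12)C(=O)N[C@@H](CC(=O)O)C(=O)COc1ccc(F)c(F)c1`, carries the change (3,4-difluorophenyl in place of phenyl on an oxygen on a saturated carbon). Among the compounds with values here, no measured step exchanges one aromatic group for a fluorinated one at this oxygen, so there is no direct guide. Since the larger swap in a 1.3-fold higher number from compound 1 to compound 2 (0.12 log units; within the scatter) left this assay almost unmoved, compound 3 is expected to stay close to compound 2, with a 1.2-fold lower number from compound 2 to compound 3 (0.07 log units; within the scatter) and an estimated value of 12000 nM, ranging from 5000 nM to 30000 nM.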

Compound 3, half-maximal inhibitory concentration: > 100000 nM
Compound 3: no number, only a limit (the forecaster's own chance of this, stated with the estimate: 10%); at least 8.3-fold (0.92 log units) between middle value and limit.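

In this assay compound 3 has no exact number, only a limit: the limit of > 100000 nM in this assay, at which 1 of the 3 values shown sits. This position is therefore not indifferent to change, even though the step from compound 1 to compound 2 stayed within the scatter. Placing 3,4-difluorophenyl on this oxygen gives an at least 7.1-fold higher number from compound 2 to compound 3 (0.85 log units; beyond the scatter), and the same group in place of (2,6-dichlorophenyl)carbonyl gives an at least 9.4-fold higher number from compound 1 to compound 3 (0.97 log units; beyond the scatter).

On these data alone, the true size of these losses stays open, since compound 3 has only a limit. Also open, as far as these compounds go, is whether a phenyl carrying one fluorine, a methoxy group or an amine would behave like phenyl or like 3,4-difluorophenyl.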